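The source may hold more compounds than are shown below. What is called first, only, known or untested is meant among the compounds shown, and "the series" means these compounds.

Compound 1, `O=c1[nH]c2ccc(Cl)cc2c(-c2ccccc2Cl)c1CCO`, gives 380000 nM in an ADME assay on HepG2 2.2.15 cells (Homo sapiens) for cytotoxicity; a higher number here means that more compound is tolerated, a lower number that less compound is tolerated. Compound 2, `O=c1c(CCO)c(-c2ccccc2Cl)c2cc(Cl)ccc2n1-c1ccccc1`, gives 26000 nM in this assay. Compound 3, `CC12CCC(C(=O)OCCc3c(-c4ccccc4Cl)c4cc(Cl)ccc4[nH]c3=O)(OC1=O)C2(C)C`, gives > 1800000 nM in this assay.

For the measured compounds named here, for compound 3 that value is a limit of the assay and not a number; compound 3 is the one compound of the three that sits at such a limit (the limit of > 1800000 nM in this assay, at which 1 of the 3 values shown sits). Compound 4, `O=C(/C=C/c1ccc(C(F)(F)F)cc1)OCCc1c(-c2ccccc2Cl)c2cc(Cl)ccc2[nH]c1=O`, differs from compound 3 by a group of 12 heavy atoms (9 carbon, 3 fluorine; one six-membered aromatic ring of carbon only) in place of a group of 11 heavy atoms (9 carbon, 2 oxygen; one five-membered non-aromatic ring of carbon only, one five-membered non-aromatic ring with 1 hetero atom), on a carbonyl carbon. Going by the values given here, the only measured step, a 15-fold lower number from compound 1 to compound 2 (1.16 log units; beyond the scatter), concerns a change on an aromatic nitrogen and so has no direct bearing on an exchange at a carbonyl carbon. Among the compounds with values here, with no step to guide it, the expectation rests on compound 1 and compound 3 alone. Compound 4 is therefore expected at 300000 nM, likely between 80000 nM and 1800000 nM, which would be an estimated step of an at least 6.0-fold lower number from compound 3 to compound 4 (0.77 log units; beyond the scatter).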

Compound 4, half-maximal cytotoxic concentration: > 1400000 nM
Compound 4: only a limit was reported (the forecaster's own chance of this, stated with the estimate: 30%); at least 4.6-fold (0.66 log units) between middle value and limit.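

For the compounds shown here, compound 3 and compound 4 each give a limit of the assay and not a number, so no step between them can be read. The compounds shown leave open whether the exchange on the carbonyl carbon changes how much compound is tolerated in this assay.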